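This account rests on a few compounds, and the source may have more. Where it says the series, first, only, none or still open, it means among the compounds named here.

The measured compounds:
compound 1 `O=Cc1ccc(-c2cn3ccnc3c(-c3ccc4ncn(C5CCCCC5)c4c3)n2)cc1`, giving 49.1% in a functional assay on HCT-15 cells (Homo sapiens) for inhibition, read by sulforhodamine B assay, with a stated time of 48 h, tested at 10 uM; a lower number here means less inhibition, a higher number more inhibition at the concentration tested (going by the name of the read-out);
compound 2 `COc1ccccc1-c1cn2ccnc2c(-c2ccc3ncn(C4CCCCC4)c3c2)n1`, giving 33.6%;
compound 3 `CCc1ccc(-c2cn3ccnc3c(-c3ccc4ncn(Cc5ccccc5)c4c3)n2)cc1`, giving 74.7%.

Compound 3 stands highest of the three numbers. Compound 1 is nearest to it, with a value that is lower beyond the scatter, and compound 2 is furthest, lower still beyond the scatter. Going by the values given here, the only step measured between neighbours is a number 15.5 percentage points lower from compound 1 to compound 2 (beyond the scatter), a modest change that turns on the aryl group carried by the shared core.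

Compound 4 `Cc1cccc(-c2cn3ccnc3c(-c3ccc4ncn(Cc5ccccc5)c4c3)n2)c1` differs from compound 3 by a single change: 3-methylphenyl in place of 4-ethylphenyl on an aromatic carbon. Among the compounds with values here, no measured step involves either of these two aryl groups, so the step from compound 1 to compound 2 is the only guide, and it shows that altering this aryl group can move the read-out modestly. Compound 4 is therefore expected to land somewhat below compound 3, with a number 12.7 percentage points lower from compound 3 to compound 4 (beyond the scatter) as the estimated step. For compound 4 the estimate in this assay is 62%, expected to fall between 42% and 80%.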

Compound 4, a percentage reported as inhibition, at one concentration (the size of the read-out at that concentration, not a potency): 35.2%
The estimate for compound 4 lay 26.8 percentage points above the measured number; the whole stated range lies above it.
By their numbers in this assay, from the lowest: compounds 2 and 4 (each within the scatter of the next); then compound 1; then compound 3.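

Exchanging 4-ethylphenyl for 3-methylphenyl on this aromatic carbon, next to the ring nitrogen, gives a number 39.5 percentage points lower from compound 3 to compound 4 (beyond the scatter) in this assay, a large step. Going by these compounds alone, the only earlier step at this position was modest and ran between 4-formylphenyl and 2-methoxyphenyl, whereas this one shows that two aryl groups, each with one six-membered aromatic ring of carbon only and no hydrogen-bond donors or acceptors, can still lie far apart in this read-out. Nothing measured here accounts for the size of this step.

Going by these compounds, the two groups differ both in their alkyl chain and in where it sits on the phenyl ring, so it remains open which of these differences carries the step. Also open, on these data alone, is how a phenyl ring bearing an amine or a carboxylic acid would read at this position.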